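Moving the pyridine nitrogen in a compound 2 analogue

A few compounds are considered here, and "the series" means these few. Any claim that something is new, unique, unknown or untested is made for them only; others in the source may bear on it.

Compounds measured so far:
compound 1, `COc1cccc(C2=N/C(=C\c3cccnc3)C(=O)O2)c1`, 100%;
compound 2, `O=C1OC(c2cccc(Br)c2)=N/C1=C\c1ccncc1`, 0%;
compound 3, `O=C1OC(c2ccccc2)=N/C1=C\c1ccncc1`, 1%.

Of the compounds shown here, three sharing one core have been tested in an assay on isolated protein for inhibition of Death-associated protein kinase 3 (Homo sapiens), tested at 10 uM; a lower number here means a weaker effect, a higher number a stronger effect of the compound at the concentration tested. Compound 2 stands lowest of the three. Its nearest neighbour is compound 3, which differs from it by hydrogen in place of bromo on an aromatic carbon; that step, a number 1 percentage points higher from compound 2 to compound 3 (within the scatter), lies within the scatter. For the measured compounds named here, the only compound far from it is compound 1, whose reading is higher by a gap well beyond the scatter.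

Compound 4, `O=C1OC(c2cccc(Br)c2)=N/C1=C\c1cccnc1`, has not yet been measured. It is built from compound 2 by the following change: pyridin-3-yl in place of pyridin-4-yl on a double-bonded chain carbon bound to a double-bonded ring carbon.

Going by the values given here, the one measured step, between compound 2 and compound 3, concerns the bromo position and not the pyridyl group, so it says nothing directly about this change. What is available is the contrast in values: compound 1, which carries pyridin-3-yl, gives a full reading, whereas compound 2 and compound 3, both carrying pyridin-4-yl, give readings near zero. Among the compounds with values here, compound 1 also differs from them on the other aromatic ring, so this is not a clean single step, but it is the only guide. A large rise is therefore expected, a number 65 percentage points higher from compound 2 to compound 4 (beyond the scatter). Compound 4 is estimated at 65%, within the range 20% to 100%.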

Compound 4, a percentage reported as inhibition, at one concentration (the size of the read-out at that concentration, not a potency): 100%
Beside the measured number, compound 4's estimate is 35 percentage points below it; measured number inside the range.
By their numbers in this assay, from the lowest: compounds 2 and 3 (each within the scatter of the next); then compounds 1 and 4 (each within the scatter of the next).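

In this assay, the contrast that compound 1 could only suggest now rests on a single change: pyridin-3-yl in place of pyridin-4-yl gives a number 100 percentage points higher from compound 2 to compound 4 (beyond the scatter) as the only difference, so the reading depends strongly on where the nitrogen sits in this pyridine ring, at least with bromo on the other aromatic ring. With pyridin-3-yl present, the exchange of methoxy for bromo gives no change at the digits printed from compound 1 to compound 4 (within the scatter) and so leaves the full reading intact, although both compounds give the highest reading in the set, and this read-out is taken at a single concentration, so any difference between them in the strength of their effect at other concentrations would not show here. No measurement available here explains why the position of the nitrogen matters so much.

The compounds shown leave open how pyridin-2-yl or a plain phenyl group would behave at this place, and whether an amine or a carboxylic acid on the pyridin-3-yl ring would be tolerated. They also leave open whether the unsubstituted phenyl of compound 3 would keep the full reading once paired with pyridin-3-yl.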